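Swapping a butyl for a phenyl on a selenocyanate carbamate

The compounds below may be only part of what the source reports. "The series", "measured", "known", "first", "only" and "open" are said of these compounds alone.

Three compounds have been measured in a functional assay on HTB-54 cells (Homo sapiens) for cytotoxicity, read by MTT assay, with a stated time of 72 h; a higher number here means a weaker inhibitor of growth, a lower number a stronger inhibitor of growth:
Compound 1, `CCCCOC(=O)Nc1ccc([Se]C#N)cc1`, gives 17200 nM.
Compound 2, `CCOC(=O)Nc1ccc([Se][Se]c2ccc(NC(=O)OCC)cc2)cc1`, gives 31200 nM.
Compound 3, `CCCCOC(=O)Nc1ccc([Se][Se]c2ccc(NC(=O)OCCCC)cc2)cc1`, gives 35200 nM.

Compound 1 carries a single selenocyanate, whereas compounds 2 and 3 are diselenides built from two carbamate-bearing parts. Among the three numbers, compound 1 sits at the low end: its gap to compound 2 lies within the usual scatter of this assay, so the two cannot be told apart, while its gap to compound 3 lies just beyond it.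

The compound still to be measured is compound 4, `N#C[Se]c1ccc(NC(=O)Oc2ccccc2)cc1`. It keeps the selenocyanate and the carbamate of compound 1 and differs from it in one place: phenyl in place of butyl on an oxygen next to a carbonyl group. Going by the values given here, no pair among the measured compounds shows what this kind of exchange does in this assay , so the direction of the step cannot be read from the data. Without any guide, the expectation is that compound 4 gives a number much like compound 1, and the step of a 1.1-fold lower number from compound 1 to compound 4 (0.06 log units; within the scatter) is expected to stay within the scatter. Compound 4 is estimated at 15000 nM, between 5000 nM and 45000 nM.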

Compound 4, concentration for 50% growth inhibition: 26200 nM
For compound 4 the middle estimate is 1.7-fold (0.24 log units) below the measured one; the measured number falls inside the stated range.
By their numbers in this assay, from the lowest: compounds 1, 4, 2 and 3 (each within the scatter of the next, the first and the last beyond it).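

In this assay, going by these compounds alone, phenyl in place of butyl on an oxygen next to a carbonyl group gives a 1.5-fold higher number from compound 1 to compound 4 (0.18 log units; within the scatter) and offers the first direct reading of an exchange at this position. The two numbers cannot be told apart, so in this one pair an open chain of 4 carbon atoms and a six-membered aromatic ring of carbon only give results that this cell test does not separate, even though the exchange adds a ring and two heavy atoms. Nothing at hand bears on why the exchange leaves the result within the scatter, and a single pair cannot show whether other groups at this position would do the same.

Still open, on these data alone, is whether a longer chain, a benzyl group or a phenyl ring carrying a chlorine atom on that same oxygen would move the number beyond the scatter. Also open, as far as these compounds go, is whether phenyl in place of butyl would give a similar result in a diselenide such as compound 3, where both carbamate-bearing parts would carry the exchange.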